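Replacing the Piperidine Sulfonyl with a Benzyl Group

The compounds below may be only part of what the source reports. "The series", "measured", "known", "first", "only" and "open" are said of these compounds alone.

Compound 3 `CC(C)S(=O)(=O)N1CCC(CCCC(=O)c2ncco2)CC1` gives 140 nM in an assay on isolated protein for inhibition of Fatty-acid amide hydrolase 1 (Homo sapiens) (a lower number here means a stronger inhibitor, a higher number a weaker inhibitor), the second highest of three numbers. Compound 1 `O=C(CCCC1CCN(C(=O)C2CCCCC2)CC1)c1ncco1` gives 45 nM and compound 2 `O=C(CCCC1CCN(S(=O)(=O)Cc2ccccc2)CC1)c1ncco1` gives 600 nM. Compound 4 `Cc1ccc(CN2CCC(CCCC(=O)c3ncco3)CC2)cc1` differs from compound 3 by 4-methylbenzyl in place of isopropylsulfonyl on an amine nitrogen in a ring. Going by the values given here, two measured steps touch this position: a 3.1-fold higher number from compound 1 to compound 3 (0.49 log units; beyond the scatter) and a 4.3-fold lower number from compound 2 to compound 3 (0.63 log units; beyond the scatter). Among the compounds with values here, neither removes the carbonyl or sulfonyl entirely, so no step matches this change directly; the nearest hint is that a benzyl-bearing group in compound 2 gave a higher number than isopropyl in compound 3. A weakening step is therefore expected, an 11-fold higher number from compound 3 to compound 4 (1.03 log units; beyond the scatter), with wide uncertainty. Compound 4 is estimated at 1500 nM, in the range 300 nM to 8000 nM.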

Compound 4, half-maximal inhibitory concentration: 400 nM
Beside the measured number, compound 4's estimate is 3.8-fold (0.57 log units) above it; low and high end bracket the measured number.
By their numbers in this assay, from the lowest: compound 1; then compound 3; then compounds 4 and 2 (each within the scatter of the next).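

The amine nitrogen in the ring need not carry a carbonyl or sulfonyl group for the compound to inhibit the enzyme: 4-methylbenzyl, which has no hydrogen-bond acceptors, gives only a modest loss, a 2.9-fold higher number from compound 3 to compound 4 (0.46 log units; beyond the scatter). The loss is larger against the cyclohexylcarbonyl group, an 8.9-fold higher number from compound 1 to compound 4 (0.95 log units; beyond the scatter), so among these three compounds the amide-type group on this nitrogen gives the lowest number. Nothing measured here explains either step. Still open, as far as these compounds go, is how a plain benzyl group, without the methyl, or a bare amine hydrogen on this nitrogen would compare.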